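Extending the Ethoxymethyl Group on a Potent Channel Blocker

The source may report more compounds than this note shows. Statements on the series, on what has been measured and on what is new or still open speak of the compounds shown alone.

Compound 1 `COCc1nc(Nc2ccc(C(F)(F)F)cc2)c2ccc(-c3ncccc3C(F)(F)F)cc2n1` and compound 2 `CCOCc1nc(Nc2ccc(C(F)(F)F)cc2)c2ccc(-c3ncccc3C(F)(F)F)cc2n1` share one core and differ only in a short side chain. In a functional assay for antagonist activity at transient receptor potential cation channel subfamily V member 1 (Homo sapiens) (on this read-out lower numbers stand for stronger inhibition and higher numbers for weaker inhibition), compound 1 gives 1.5 nM, and compound 2 gives 0.9 nM. Of the two numbers compound 2 holds the lower one, its nearest neighbour being compound 1, yet the step of a 1.7-fold lower number from compound 1 to compound 2 (0.22 log units; within the scatter) is too small to be told apart from the spread of repeated measurements, so the two compounds cannot be ranked.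

Compound 3 `CC(C)OCc1nc(Nc2ccc(C(F)(F)F)cc2)c2ccc(-c3ncccc3C(F)(F)F)cc2n1` carries the same kind of change one position further out: methyl in place of hydrogen on a saturated chain carbon bound to an oxygen on a saturated carbon and a saturated chain carbon. Within the data shown here, the only measured step that bears on this is a 1.7-fold lower number from compound 1 to compound 2 (0.22 log units; within the scatter), which added the first methyl at this same chain and left the read-out essentially where it was. Among the measured compounds shown here, nothing measured so far shows a lengthening of this chain producing a shift beyond the scatter, and the second methyl is expected to behave alike. Compound 3 is therefore expected to give about 1 nM in this assay, with a range from 0.4 nM to 2.5 nM. The step of a 1.1-fold higher number from compound 2 to compound 3 (0.05 log units; within the scatter) is expected to stay within the scatter.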

Compound 3, half-maximal inhibitory concentration: 0.3 nM
The estimate for compound 3 lay 3.3-fold (0.52 log units) above the measured number; the whole stated range lies above it.
By their numbers in this assay, from the lowest: compound 3; then compounds 2 and 1 (each within the scatter of the next).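

In this assay, the second methyl did what the first did not: turning ethoxymethyl into isopropoxymethyl gives a 3.0-fold lower number from compound 2 to compound 3 (0.48 log units; beyond the scatter) and so moves the read-out beyond the scatter, whereas the first methyl added to this chain gave only a 1.7-fold lower number from compound 1 to compound 2 (0.22 log units; within the scatter) and stayed within it. The same kind of change at neighbouring stages of one side chain therefore need not count equally, and taken as a whole, the change from methyl to isopropyl on the oxygen gives a 5.0-fold lower number from compound 1 to compound 3 (0.70 log units; beyond the scatter) and sets compound 3 apart from both other compounds as the most potent of the three. Nothing given here explains why the isopropyl group gives the lowest number.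

Going by these compounds, it remains open whether the branching itself matters or simply the added carbon, since a straight propyl chain on the same oxygen would be needed to tell these apart. Equally open, on these data alone, is how far this trend runs, for example whether a tert-butyl or cyclopropyl group on the oxygen would take the number lower still or give some of the gain back.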